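The source may report more compounds than this note shows. Statements on the series, on what has been measured and on what is new or still open speak of the compounds shown alone.

Measured compounds in an assay on isolated protein for inhibition of protein deacetylase HDAC6 (Homo sapiens), read by fluorescence, with a stated time of 90 min; on this read-out lower numbers stand for stronger inhibition and higher numbers for weaker inhibition:
compound 1, `Cc1cc(C)cc(C(=O)N(Cc2ccc(C(=O)NO)cc2)Cc2nnnn2Cc2ccccc2)c1`, gives 80 nM
compound 2, `O=C(NO)c1ccc(CNCc2nnnn2Cc2ccccc2)cc1`, gives 100 nM
compound 3, `CC(C)c1ccc(C(=O)N(Cc2ccc(C(=O)NO)cc2)Cc2nnnn2Cc2ccccc2)cc1`, gives 320 nM

Compound 2 stands second highest of the three numbers. Its nearest neighbour is compound 1, with a 1.3-fold higher number from compound 1 to compound 2 (0.10 log units; within the scatter), a difference within the scatter; its furthest is compound 3, with a 3.2-fold higher number from compound 2 to compound 3 (0.51 log units; beyond the scatter), a modest step beyond the scatter. The measured steps all concern the amine nitrogen: a 4.0-fold higher number from compound 1 to compound 3 (0.60 log units; beyond the scatter) exchanges one aryl carbonyl for another there, and the two others add or remove such a group.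

Compound 4, `O=C(NO)c1ccc(CNCc2nnnn2C2CCCCC2)cc1`, differs from compound 2 elsewhere: cyclohexyl in place of benzyl on an aromatic nitrogen. Among the compounds with values here, none of the three measured steps touches this position, so no measured step bears directly on the change. Within the data shown here, with no relevant precedent, the expectation is a step of no size beyond the scatter, in neither direction, so that a 1.3-fold higher number from compound 2 to compound 4 (0.11 log units; within the scatter) is the estimated outcome. Compound 4 is therefore expected to give about 130 nM in this assay, with a likely range from 50 nM to 350 nM.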

Compound 4, half-maximal inhibitory concentration: 120 nM
Estimate against measurement, compound 4: 1.1-fold (0.03 log units) above, and the stated range covers the measured number.
By their numbers in this assay, from the lowest: compounds 1, 2 and 4 (each within the scatter of the next); then compound 3.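

In this assay, within the data shown here, the exchange of benzyl for cyclohexyl on the aromatic nitrogen gives a 1.2-fold higher number from compound 2 to compound 4 (0.08 log units; within the scatter) and is the first measured change at this position, which none of the earlier steps touched. A six-membered aromatic ring of carbon only gives way here to a six-membered non-aromatic ring of carbon only, and the read-out does not separate the two groups. Nothing available on these compounds speaks to what lies behind this result.

The compounds shown leave open whether a methyl group, a longer chain ending in an amine or one ending in a carboxylic acid on this nitrogen would read the same way. They also leave open whether cyclohexyl would match benzyl with an aryl carbonyl on the amine nitrogen, as in compound 1 and compound 3.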